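This account rests on a few compounds, and the source may have more. Where it says the series, first, only, none or still open, it means among the compounds named here.

Notes on the series. Three measured compounds share one core and differ only in the hydroxy pattern of the ring on the carbon with a double bond to nitrogen. Compound 1 `Oc1ccc(O)c(/C=N/c2ccc(OCc3ccccc3)cc2)c1` gives 1230 nM in an assay on isolated protein for inhibition of Amine oxidase [flavin-containing] B (Homo sapiens), read by fluorescence and Amplex Red, with stated times of 15 min and 20 min; a higher number here means a weaker inhibitor, a lower number a stronger inhibitor. Compound 2 `Oc1cccc(/C=N/c2ccc(OCc3ccccc3)cc2)c1O` gives 6870 nM in this assay, and compound 3 `Oc1ccccc1/C=N/c1ccc(OCc2ccccc2)cc1` gives 25100 nM. Compound 3 thus stands at the highest number of the three: a 3.7-fold higher number from compound 2 to compound 3 (0.56 log units; beyond the scatter) and a 20-fold higher number from compound 1 to compound 3 (1.31 log units; beyond the scatter), both steps that remove one hydroxy group, while a 5.6-fold higher number from compound 1 to compound 2 (0.75 log units; beyond the scatter) relocates one.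

Compound 4 `Oc1ccc(Cl)cc1/C=N/c1ccc(OCc2ccccc2)cc1` differs from compound 3 by chloro in place of hydrogen on an aromatic carbon. Among the measured compounds shown here, no measured step adds a chloro group, or any group other than hydroxy, so the recorded steps bear on this change only indirectly: they show that this ring responds to its substitution, with steps of the size of a 3.7-fold higher number from compound 2 to compound 3 (0.56 log units; beyond the scatter) and a 20-fold higher number from compound 1 to compound 3 (1.31 log units; beyond the scatter) for a single hydroxy group. Whether a chloro group at the place described shifts the number cannot be read from them. The step of a 1.1-fold lower number from compound 3 to compound 4 (0.06 log units; within the scatter) is therefore expected not to go beyond the scatter in either direction. Compound 4 is estimated at 22000 nM, with a range from 7000 nM to 70000 nM.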

Compound 4, half-maximal inhibitory concentration: 24800 nM
The estimate for compound 4 lay 1.1-fold (0.05 log units) below the measured number; the measured number falls inside the stated range.
By their numbers in this assay, from the lowest: compound 1; then compound 2; then compounds 4 and 3 (each within the scatter of the next).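

In this assay, chloro on the aromatic carbon para to a hydroxy group gives the first non-hydroxy substituent in the series, and a 1.0-fold lower number from compound 3 to compound 4 (0.01 log units; within the scatter) means that compound 3 and compound 4 cannot be told apart, so at this place the chloro group makes no measurable difference to the 2-hydroxyphenyl compound. The same carbon bears a hydroxy group in compound 1, and a 20-fold higher number from compound 1 to compound 4 (1.30 log units; beyond the scatter) shows that chloro does not match hydroxy there, so the low number of compound 1 goes with hydroxy at this place and not with just any substituent; a 3.6-fold higher number from compound 2 to compound 4 (0.56 log units; beyond the scatter) likewise leaves the 5-chloro-2-hydroxyphenyl compound on the high side of the 2,3-dihydroxyphenyl compound. Nothing available here gives a measured reason for either the gap to hydroxy or the absence of a chloro effect.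

Open, on these data alone, is whether an amine, a methoxy group or a carboxylic acid at this place would come closer to hydroxy or stay with chloro. Also open, as far as these compounds go, is whether chloro on another carbon of this ring, or alongside the hydroxy groups of compound 1, would read the same.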